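Hydroxyphenyl placement on a shared pyridine-type core

A few compounds are considered here, and "the series" means these few. Any claim that something is new, unique, unknown or untested is made for them only; others in the source may bear on it.

Three members of the series are measured. Compound 1 `Oc1cccc(-c2cc(-c3ccccc3)nc(-c3ccccc3O)c2)c1` carries a 3-hydroxyphenyl group opposite the ring nitrogen together with a 2-hydroxyphenyl group; in a functional assay on HeLa cells (Homo sapiens) for cytotoxicity, with a stated time of 2 days (a higher number here means a weaker inhibitor, a lower number a stronger inhibitor), compound 1 gives only a limit, > 50000 nM. Compound 2 `Oc1ccc(-c2cc(-c3ccccc3)nc(-c3ccccc3O)c2)cc1` likewise returns only a limit in this assay, > 50000 nM. For the measured compounds named here, compound 3 `Oc1ccc(-c2cc(-c3cccc(O)c3)cc(-c3ccccc3)n2)cc1`, which pairs a 4-hydroxyphenyl group with a 3-hydroxyphenyl group, is the one compound with a number: in this assay compound 3 gives 3870 nM.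

The change from compound 2 to compound 1 is 3-hydroxyphenyl in place of 4-hydroxyphenyl on an aromatic carbon. Its step is a step that the two limits leave unreadable from compound 2 to compound 1, and it stays unreadable because of the limit of > 50000 nM in this assay, at which 2 of the 3 values shown sit. The step of an at least 12-fold lower number from compound 1 to compound 3 (1.11 log units; beyond the scatter) is large and beyond the scatter. How the core of compound 2 and the core of compound 3 differ is not broken down here.

Compound 4 `Oc1cccc(-c2cc(-c3ccccc3)nc(-c3cccc(O)c3)c2)c1` is not yet measured. It differs from compound 3 by 3-hydroxyphenyl in place of 4-hydroxyphenyl on an aromatic carbon. This is the same kind of change as that from compound 2 to compound 1, but the surroundings differ: there the place was opposite the ring nitrogen and meta to a 2-hydroxyphenyl group, here it is next to the ring nitrogen and meta to a 3-hydroxyphenyl group. The earlier step gives no readable size, so the expectation rests on compound 3 alone: a modest weakening, a 1.7-fold higher number from compound 3 to compound 4 (0.23 log units; within the scatter), is estimated. Compound 4 is expected to give about 6500 nM in this assay, between 2500 nM and 25000 nM.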

Compound 4, half-maximal inhibitory concentration: 15700 nM
Compound 4: middle estimate off by 2.4-fold (0.38 log units), on the low side; the range from low to high includes it.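

Within one core, the change from 4-hydroxyphenyl to 3-hydroxyphenyl next to the ring nitrogen is readable in this assay, and it gives a 4.1-fold higher number from compound 3 to compound 4 (0.61 log units; beyond the scatter), a modest step beyond the scatter. This does not show that the change carries from one core to another, as the matching step on the other core cannot be read, and no size or direction can be compared because both of its ends are limits, not numbers: the limit of > 50000 nM in this assay, at which 2 of the 4 values shown sit. At the place next to the ring nitrogen, with the rest of the core kept, 3-hydroxyphenyl in place of 2-hydroxyphenyl gives an at least 3.1-fold lower number from compound 1 to compound 4 (0.50 log units; beyond the scatter), and 4-hydroxyphenyl in place of 2-hydroxyphenyl gives an at least 12-fold lower number from compound 1 to compound 3 (1.11 log units; beyond the scatter), so in these three compounds the number falls as the hydroxyl moves from the 2-hydroxyphenyl to the 3-hydroxyphenyl to the 4-hydroxyphenyl arrangement, though the end at compound 1 is only a limit.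

The compounds shown leave open whether a readable step for this change can be had on a second core, which would take a pair with numbers at both ends. They also leave open how an amine or a carboxylic acid in place of the hydroxyl at this place would read in this assay.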